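Replacing the aryl group of compound 2

The source may report more compounds than this note shows. Statements on the series, on what has been measured and on what is new or still open speak of the compounds shown alone.

Compound 1 `O=C(CCc1cccc2c1B(O)OC2)Nc1cccc(I)c1` gives 630 nM
Compound 2 `COc1ccc(-c2cccc(NC(=O)CCc3cccc4c3B(O)OC4)c2)cc1` gives 48 nM

Going by the values given here, both values come from a functional assay on SK-OV-3 cells (Homo sapiens) for antiproliferative activity, read by MTT assay, with a stated time of 72 h (a higher number here means a weaker inhibitor, a lower number a stronger inhibitor), and compound 2 holds the lower of the two numbers so far. Compound 3 `COc1cc(OC)cc(-c2cccc(NC(=O)CCc3cccc4c3B(O)OC4)c2)c1` alters compound 2 in one place: 3,5-dimethoxyphenyl in place of 4-methoxyphenyl on an aromatic carbon. Among the compounds with values here, only one measured step bears on this change: a 13-fold lower number from compound 1 to compound 2 (1.12 log units; beyond the scatter), which is large and beyond the scatter. That step exchanged iodo for 4-methoxyphenyl, whereas the present change exchanges 4-methoxyphenyl for 3,5-dimethoxyphenyl, so its size does not carry over. The data contain no comparison between two substituted phenyl groups, which leaves the direction poorly defined. In this assay no step beyond the scatter is expected, with a slight lean towards a higher number. The expected step is a 1.5-fold higher number from compound 2 to compound 3 (0.16 log units; within the scatter) in this estimate. For compound 3 the estimated value is 70 nM, with an expected range from 20 nM to 250 nM as the span of likely results.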

Compound 3, half-maximal inhibitory concentration: 44 nM
Compound 3: the middle estimate sits 1.6-fold (0.20 log units) above what was measured; measured number inside the range.
By their numbers in this assay, from the lowest: compounds 3 and 2 (each within the scatter of the next); then compound 1.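

In this assay, 3,5-dimethoxyphenyl in place of 4-methoxyphenyl on this aromatic carbon gives a 1.1-fold lower number from compound 2 to compound 3 (0.04 log units; within the scatter), so these two substituted phenyl groups cannot be told apart here. Measured against iodo, the new group gives a 14-fold lower number from compound 1 to compound 3 (1.16 log units; beyond the scatter), a large step like a 13-fold lower number from compound 1 to compound 2 (1.12 log units; beyond the scatter), so the large step away from iodo is now seen with two different methoxyphenyl groups rather than with one alone. Nothing measured here accounts for either the large steps away from iodo or the lack of separation between the two methoxyphenyl groups.

Still open is whether a methoxy group matters at all, since neither an unsubstituted phenyl nor a phenyl carrying an amine or a carboxylic acid in place of methoxy appears among these compounds. Also open, as far as these compounds go, is whether an aromatic ring is needed on this carbon, which a morpholine or a longer alkyl chain in its place would address, and whether any of this holds with a change to the shared core.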